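Adding Chlorine to a Purine-Like Core: Expected Effect

A few compounds are considered here, and "the series" means these few. Any claim that something is new, unique, unknown or untested is made for them only; others in the source may bear on it.

Compound 1 `CCCCCCC(CCO)n1cnc2c(Cl)ncnc21` and compound 2 `CCCCCCC(CCO)n1cnc2cncnc21` share one core; compound 3 `CCCCCCCCCC(CCO)n1cnc2c(N)ncnc21` and compound 4 `CCCCCCCCCC(CCO)n1cnc2c(N)nc(Cl)nc21` share another, and the difference between the two cores is not broken down here. In a functional assay on SW480 cells (Homo sapiens) for antiproliferative activity, read by MTT assay, with a stated time of 48 h (a higher number here means a weaker inhibitor, a lower number a stronger inhibitor), compound 1 gives 16700 nM. Compound 2 reaches only a limit of > 50000 nM in this assay. The change from compound 2 to compound 1 is chloro in place of hydrogen on an aromatic carbon, and it produced an at least 2.9-fold lower number from compound 2 to compound 1 (0.47 log units; beyond the scatter), a size that is known only as a bound because of the limit of > 50000 nM in this assay, at which 1 of the 3 values shown sits. Compound 3 gives 6030 nM in this assay. Compound 4 differs from compound 3 by chloro in place of hydrogen on an aromatic carbon, the same kind of change, though here the chloro sits between two ring nitrogen atoms and meta to an amino group, rather than next to the ring nitrogen and ortho to a fused ring. Compound 4 is expected to show a 2.0-fold lower number from compound 3 to compound 4 (0.30 log units; within the scatter), resting on the earlier step of an at least 2.9-fold lower number from compound 2 to compound 1 (0.47 log units; beyond the scatter). Compound 4 is therefore estimated at 3000 nM.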

Compound 4, half-maximal inhibitory concentration: 12200 nM
For compound 4 the middle estimate is 4.1-fold (0.61 log units) below the measured one; measured number outside the range, above it.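

In this assay, chloro in place of hydrogen on an aromatic carbon gives a 2.0-fold higher number from compound 3 to compound 4 (0.31 log units; beyond the scatter), so the change did not carry over from the earlier core with the same direction, and the two steps clearly differ: the same change on two cores in this assay, an at least 2.9-fold lower number (0.47 log units; beyond the scatter) from compound 2 to compound 1 and a 2.0-fold higher number (0.31 log units; beyond the scatter) from compound 3 to compound 4, at least 6.0-fold (0.78 log units) apart, beyond the scatter of two such steps. The size of the earlier step is known only as a bound, and compound 2 gives > 50000 nM, which is a limit of the assay. The two cores differ in more than one place and the chloro sits in a different place on each, so these steps do not show which difference matters.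

Only one replacement at each place is shown here. On these data alone, whether a bromo or a methyl group between two ring nitrogen atoms on the core of compound 3 would behave like the chloro of compound 4 stays open.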